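A few compounds are considered here, and "the series" means these few. Any claim that something is new, unique, unknown or untested is made for them only; others in the source may bear on it.

Compound 1 `CC/N=C(\S)CCn1nc(-c2ccccc2)ccc1=O` is the starting point of this set. In a functional assay on the whole organism (stomach) with Rattus norvegicus as the target (on this read-out lower numbers stand for an effect already at smaller amounts and higher numbers for an effect only at larger amounts of compound), compound 1 gives 100 mg/kg, which is the only actual number shown among the three measured compounds. Compound 2 `Cc1cc(=O)n(CCC(=N)S)nc1-c1ccccc1` reaches only the limit of this assay, reported as > 100 mg/kg. Compound 3 `Cc1ccc(=O)n(CC(=N)S)n1` likewise sits at the limit, reported as > 100 mg/kg. The picture is summed up by the limit of > 100 mg/kg in this assay, at which 2 of the 3 values shown sit, so the whole set acts only at large amounts. Compound 4 `N=C(S)CCCCCCn1nc(-c2ccccc2)ccc1=O` has not yet been measured. It differs from compound 1 by a group of 7 heavy atoms (5 carbon, 1 nitrogen, 1 sulfur; no ring) in place of a group of 5 heavy atoms (3 carbon, 1 nitrogen, 1 sulfur; no ring), on a saturated chain carbon, two bonds along the chain from an aromatic nitrogen. Going by the values given here, no measured step of this kind exists to lean on, so the step of no change at the digits printed from compound 1 to compound 4 (within the scatter) is expected to stay within the scatter in either direction. Compound 4 is therefore estimated at 100 mg/kg, with an expected range from 40 mg/kg to 250 mg/kg.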

Compound 4, dose for half-maximal effect: > 100 mg/kg
Compound 4 was reported as a limit; the forecaster's own chance of this, stated with the estimate: 50%; the middle value lies on the limit itself.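

In this assay the change at this position gives a number no lower from compound 1 to compound 4 (the limit leaves the size open), so the group of 7 heavy atoms brings no visible gain over the group of 5 heavy atoms. The size of this step cannot be read: the value of compound 4 is a limit of the assay, not a number. The set now gathers even more firmly at one end: the limit of > 100 mg/kg in this assay, at which 3 of the 4 values shown sit.

On these data alone, it remains open whether any group at this position can bring the effect down to smaller amounts, such as a carboxylic acid or an amine at the end of the chain. As far as these compounds go, only compound 1 carries an actual number, so the size of a change at this position remains unknown.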